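A few compounds are considered here, and "the series" means these few. Any claim that something is new, unique, unknown or untested is made for them only; others in the source may bear on it.

Of the compounds shown here, three of one series have been measured in a functional assay on ileum for inhibition of histamine H1 receptor (Cavia porcellus); on this read-out lower numbers stand for stronger inhibition and higher numbers for weaker inhibition. Compound 1 `C=CCOCCn1c(N2CCCN(C)CC2)nc2ccccc21` gives 10 nM. Compound 2 `CCCN1CCN(c2nc3ccccc3n2CCOCC)CC1` gives 16 nM in this assay. Compound 3 `C#CCOCCn1c(N2CCN(C)CC2)nc2ccccc21` gives 12 nM in this assay, the second highest of the three numbers, with compound 1 nearest and compound 2 furthest; both gaps lie within the usual scatter, so no order among the three can be read from these figures.

Compound 4 `COCCCn1c(N2CCN(C)CC2)nc2ccccc21` has not yet been measured. It differs from compound 3 in one place: methoxymethyl in place of propargyloxy on a saturated chain carbon, two bonds along the chain from an aromatic nitrogen. The triple bond of the side chain is thus lost, while a hydrogen-bond acceptor remains in the chain.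

Going by the values given here, no measured step of a comparable kind exists in this set, so the expectation rests on the narrow spread of the three measured compounds: compound 1 at 10 nM, compound 2 at 16 nM and compound 3 at 12 nM lie within the scatter of one another despite different side chains. The step of a 1.3-fold higher number from compound 3 to compound 4 (0.12 log units; within the scatter) is therefore expected to be small, at most a modest weakening not clearly beyond the scatter. Compound 4 is estimated at 16 nM, with a range from 6 nM to 45 nM.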

Compound 4, half-maximal inhibitory concentration: 860 nM
Estimate against measurement, compound 4: 54-fold (1.73 log units) below; measured number outside the range, above it.
By their numbers in this assay, from the lowest: compounds 1, 3 and 2 (each within the scatter of the next); then compound 4.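

Going by these compounds alone, compound 3 and compound 4 give the first measured step at this position, and it is large in this assay (a 72-fold higher number from compound 3 to compound 4 (1.86 log units; beyond the scatter)), so this assay is sensitive to the change from 2-(propargyloxy)ethyl to 3-methoxypropyl on the shared core. Both side chains carry one hydrogen-bond acceptor and no donor, so in this pair the presence of an acceptor in the chain did not keep the number low. Nothing available explains the size of this step.

Within the data shown here, the single pair cannot separate the loss of the triple bond from the other differences between the two chains. From the compounds shown here alone, whether a 2-methoxyethyl chain, a butyl chain or a chain ending in an amine on this core would sit nearer compound 3 or compound 4 remains open.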